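A few compounds are considered here, and "the series" means these few. Any claim that something is new, unique, unknown or untested is made for them only; others in the source may bear on it.

Working notes on the series in a functional assay on Ehrlich cells (Mus musculus) for cytotoxicity, read by trypan blue exclusion, with a stated time of 2 h, tested at 25 ug/mL; on this read-out lower numbers stand for a weaker effect and higher numbers for a stronger effect at the one concentration tested. Compound 1 `N#CC1=C(N)N(c2ccc(S(N)(=O)=O)cc2)C2=C(CCCC2)C1/C=C/c1ccccc1` gives 70% in this assay. Compound 2 `N#CC1=C(N)N(c2ccc(S(N)(=O)=O)cc2)C2=C(CCCC2)C1c1ccc([N+](=O)[O-])cc1` gives 5% in this assay, the lowest of the two numbers recorded so far; its nearest neighbour is compound 1, and the gap is beyond the scatter.

The unmeasured compound 3 `N#CC1=C(N)N(c2ccc(S(N)(=O)=O)cc2)C2=C(CCCC2)C1c1cccs1` differs from compound 2 at a single place: thiophen-2-yl in place of 4-nitrophenyl on a saturated ring carbon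

Among the measured compounds shown here, only one measured step bears on this change, since it is the one step at the same saturated ring carbon: a number 65 percentage points lower from compound 1 to compound 2 (beyond the scatter). That step shows that this position decides much of the read-out, but it compares 2-phenylethenyl with 4-nitrophenyl, and neither is thiophen-2-yl, so the direction for compound 3 cannot be read from it directly. Since compound 2 with 5% sits at the low end, a move upward is expected to be more likely than a further fall, though the size is open.

For compound 3 a middle estimate of 30% is expected, with a range from 5% to 65%. The expected step is a number 25 percentage points higher from compound 2 to compound 3 (beyond the scatter).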

Compound 3, a percentage reported as activity, at one concentration (the size of the read-out at that concentration, not a potency): 5%
Compound 3: the middle estimate sits 25 percentage points above what was measured; the range from low to high includes it.
By their numbers in this assay, from the lowest: compounds 2 and 3 (each within the scatter of the next); then compound 1.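

In this assay, the step of no change at the digits printed from compound 2 to compound 3 (within the scatter) shows that at this saturated ring carbon, thiophen-2-yl and 4-nitrophenyl cannot be told apart, although they differ in ring size, heavy-atom count and hetero atoms. The step of a number 65 percentage points lower from compound 1 to compound 3 (beyond the scatter) shows that the large gap first seen with compound 2 is not peculiar to 4-nitrophenyl, since it recurs with a five-membered aromatic ring carrying sulfur; among these three compounds, only compound 1, with 2-phenylethenyl, stands apart. No evidence at hand accounts for the shared low read-out of compound 2 and compound 3 or for the higher read-out of compound 1.

The compounds shown leave open whether the read-out of compound 1 depends on the double bond of 2-phenylethenyl or on the longer link to its phenyl ring, a question that a 2-phenylethyl chain or an unsubstituted phenyl group at the same carbon would address. Also open, going by these compounds, is whether compound 2 and compound 3 would remain indistinguishable at concentrations other than the single one tested, or with an aliphatic group such as cyclohexyl at this position.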